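Single stereocentre inversion in compound 2

This account rests on a few compounds, and the source may have more. Where it says the series, first, only, none or still open, it means among the compounds named here.

Compound 1 `CCCCC[C@H](O)/C=C/[C@H]1C=CC(=O)/C1=C/CCCCCC(=O)O` and compound 2 `CCCCC[C@@H](O)/C=C/[C@@H]1C=CC(=O)/C1=C/CCCCCC(=O)O` share all atoms and bonds and differ only in configuration as drawn. In a functional assay on Colon 26 cells (Rattus norvegicus) for antiproliferative activity against Colon 26 (Mus musculus) (on this read-out higher numbers stand for weaker inhibition and lower numbers for stronger inhibition), compound 1 gives 0.57 ug/mL and compound 2 gives 0.5 ug/mL, the two numbers lying within the scatter of each other. Compound 3 `CCCCC[C@H](O)/C=C/[C@@H]1C=CC(=O)/C1=C/CCCCCC(=O)O` differs from compound 2 thus: the two compounds have the same atoms and bonds and differ only in configuration as drawn: 1 of 4 stereo elements differ; a stereocentre at a saturated chain carbon is drawn R in compound 2 and S in compound 3. For the measured compounds named here, the only measured step that bears on this is a 1.1-fold lower number from compound 1 to compound 2 (0.06 log units; within the scatter), an inversion of both stereocentres. For compound 3 no step beyond the scatter is therefore expected in this assay, a 1.1-fold higher number from compound 2 to compound 3 (0.04 log units; within the scatter). The estimate for compound 3 is 0.55 ug/mL, between 0.25 ug/mL and 1.2 ug/mL.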

Compound 3, half-maximal inhibitory concentration: 0.35 ug/mL
Compound 3: middle estimate off by 1.6-fold (0.20 log units), on the high side, and the stated range covers the measured number.
By their numbers in this assay, from the lowest: compounds 3, 2 and 1 (each within the scatter of the next).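

In this assay, each stereocentre can now be read alone: inverting the saturated chain carbon gives a 1.4-fold lower number from compound 2 to compound 3 (0.15 log units; within the scatter), and inverting the saturated ring carbon gives a 1.6-fold lower number from compound 1 to compound 3 (0.21 log units; within the scatter). The earlier pair showed only both centres inverted together, so it could not exclude separate steps at each centre. Neither single inversion moves the number beyond the scatter in this assay.

Still open, going by these compounds, is the pairing of an R chain carbon with an S ring carbon. Also open, on these data alone, is whether an amine at the saturated chain carbon, or a longer chain, would give a step beyond the scatter.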